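Nitropyrrole hydrazide series: cytotoxicity on Vero cells

A few compounds are considered here, and "the series" means these few. Any claim that something is new, unique, unknown or untested is made for them only; others in the source may bear on it.

Measured so far:
compound 1 `O=C(NNC(=S)Nc1ccc(F)cc1)c1cc([N+](=O)[O-])c[nH]1`: 331000 nM
compound 2 `COc1ccc(OC)c(NC(=O)NNC(=O)c2cc([N+](=O)[O-])c[nH]2)c1`: 333000 nM
compound 3 `COc1cc(NC(=S)NNC(=O)c2cc([N+](=O)[O-])cn2C)cc(OC)c1OC`: 392000 nM

Three compounds of the series have been run in an ADME assay on Vero cells (Chlorocebus sabaeus) for cytotoxicity, read by MTT assay, with a stated time of 72 h; on this read-out lower numbers stand for stronger inhibition and higher numbers for weaker inhibition. In this assay compound 1 gives 331000 nM, compound 2 gives 333000 nM and compound 3 gives 392000 nM. Compound 3 holds the highest of the three numbers, yet its gap to compound 2 and its gap to compound 1 are both within the scatter of repeated measurements, so the three values cannot be told apart.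

Compound 4 `COc1cc(NC(=S)NNC(=O)c2cc([N+](=O)[O-])c[nH]2)cc(OC)c1OC` has not yet been measured in this assay. It differs from compound 3 in one place: hydrogen in place of methyl on an aromatic nitrogen. Going by the values given here, no pair of measured compounds differs by this change alone, so its size cannot be read from the data. Compound 1 and compound 2 carry the unmethylated ring nitrogen and sit close to compound 3.

The step from compound 3 to compound 4 is therefore expected to be small, a 1.2-fold lower number from compound 3 to compound 4 (0.06 log units; within the scatter), with no direction beyond the scatter. Compound 4 is estimated at 340000 nM, expected to fall between 200000 nM and 560000 nM.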

Compound 4, half-maximal inhibitory concentration: 328000 nM
Compound 4: middle estimate off by 1.0-fold (0.02 log units), on the high side; the measured number falls inside the stated range.
By their numbers in this assay, from the lowest: compounds 4, 1, 2 and 3 (each within the scatter of the next).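

Hydrogen in place of methyl on the aromatic nitrogen of the five-membered ring, with the rest of the molecule held fixed, gives in this assay a reading of a 1.2-fold lower number from compound 3 to compound 4 (0.08 log units; within the scatter), so compound 3 and compound 4 cannot be told apart. Going by these compounds alone, this is the first direct reading of the change, as compound 1 and compound 2 differ from compound 3 in more than one place and could not isolate it. In this one pair, going from 1-methyl-4-nitro-1H-pyrrol-2-yl to 4-nitro-1H-pyrrol-2-yl leaves the cytotoxicity reading on Vero cells unresolved from the scatter, and no measurement at hand bears on why the two compounds read alike.

Still open, on these data alone, is whether a larger group on this nitrogen, such as a benzyl group or a chain ending in a carboxylic acid or an amine, would give a step beyond the scatter. Also open, as far as these compounds go, is whether hydrogen in place of methyl at this position reads the same way when the group at the far end of the molecule is that of compound 1 or compound 2 rather than that of compound 3 and compound 4.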